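Ethoxycarbonyl to carboxy on the sulfonamide chain

This account rests on a few compounds, and the source may have more. Where it says the series, first, only, none or still open, it means among the compounds named here.

In an ADME assay on MDCK cells (Canis lupus familiaris) for cytotoxicity, read by MTT assay, with a stated time of 24 h (a lower number here means that less compound is tolerated, a higher number that more compound is tolerated), compound 3 `CCOC(=O)CCN(Cc1cccs1)S(=O)(=O)c1ccc(Br)cc1` gives > 154000 nM, which is a limit and not a number. Compound 1 `N#CCCN(Cc1cccs1)S(=O)(=O)c1ccc(Br)cc1` gives > 173000 nM, also a limit. Compound 2 `CCCN(Cc1cccs1)S(=O)(=O)c1ccc(Br)cc1` gives > 178000 nM, again a limit. Compound 3 therefore has no numerical position in the series, and neither of its two neighbours offers one.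

The next structure, compound 4 `O=C(O)CCN(Cc1cccs1)S(=O)(=O)c1ccc(Br)cc1`, has hydrogen in place of ethyl on an oxygen next to a carbonyl group, (hydrogen in place of ethyl on an oxygen next to a carbonyl group). The same difference reads ethoxycarbonyl to carboxy.

Three measured steps change the end of the same chain: a step that the two limits leave unreadable from compound 1 to compound 2, a step that the two limits leave unreadable from compound 1 to compound 3 and a step that the two limits leave unreadable from compound 2 to compound 3. None of them gives a size, and none involves carboxy. The expectation rests only on the fact that cyano, methyl and ethoxycarbonyl all ended in limits, with compound 3 at > 154000 nM as the closest case. No step beyond the usual scatter is expected in this assay, and no direction can be assigned. The expected change is a step that the limit leaves unreadable from compound 3 to compound 4, and a further limit is the most likely report. For compound 4 the estimated value is 165000 nM, with an expected range from 100000 nM to 250000 nM.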

Compound 4, half-maximal cytotoxic concentration: > 164000 nM
Compound 4 was reported as a limit; the forecaster's own chance of this, stated with the estimate: 85%; the middle value is on the limit's open side.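

Compound 4, like compound 1, compound 2 and compound 3, is reported only as a limit, so none of the steps from compound 1, compound 2 or compound 3 to compound 4 can be read. The compounds shown leave open where any of the four lies in this assay, and whether the end of the chain matters there at all.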